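Trading an Open-Chain Ether for a Small Ring Ether

A few compounds are considered here, and "the series" means these few. Any claim that something is new, unique, unknown or untested is made for them only; others in the source may bear on it.

Of the compounds shown here, three built on one shared core have been measured in an assay on HEK293 cells for displacement of a labelled ligand from growth hormone secretagogue receptor type 1 (Homo sapiens), with a stated time of 60 min; a higher number here means a weaker inhibitor, a lower number a stronger inhibitor. Compound 1 `Cc1ccccc1-c1nc2cn(-c3cccc(C#N)c3)nc2c(=O)n1CC1CCCN(C(C)C)C1` gives 32 nM. Compound 2 `CCO[C@@H](C)CN1CCC[C@H](Cn2c(-c3cccnc3C)nc3cn(-c4cccc(OC)c4)nc3c2=O)C1` gives 5 nM, the lowest number of the three; compound 1 stands at a higher number beyond the scatter, and compound 3 `Cc1ncccc1-c1nc2cn(-c3ccccc3)nc2c(=O)n1C[C@H]1CCCN(C[C@H]2CCCO2)C1` stands furthest away, at 190 nM. Compound 2 is therefore the strongest inhibitor of the measured set.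

Compound 4 `COc1cccc(-n2cc3nc(-c4cccnc4C)n(C[C@H]4CCCN(CC5CCO5)C4)c(=O)c3n2)c1` has not yet been measured. It differs from compound 2 in a single spot: oxetan-2-yl in place of 1-ethoxyethyl on a saturated chain carbon bound to an amine nitrogen in a ring. The open-chain ether, with its defined stereocentre, gives way to a small ring ether at the same place.

Going by the values given here, no pair of measured compounds differs only at this spot, so there is no measured step to lean on. Compound 3 also carries a ring ether on that nitrogen, but it differs from compound 2 in another place too, so all it shows is that compound 3 reaches 190 nM.

The expectation is a modest move toward a higher number, a step of a 3.0-fold higher number from compound 2 to compound 4 (0.48 log units; beyond the scatter) that is probably somewhat beyond the scatter. For compound 4 the estimate in this assay is 15 nM, with a range from 4 nM to 60 nM.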

Compound 4, half-maximal inhibitory concentration: 23 nM
Compound 4: middle estimate off by 1.5-fold (0.19 log units), on the low side; low and high end bracket the measured number.
By their numbers in this assay, from the lowest: compound 2; then compounds 4 and 1 (each within the scatter of the next); then compound 3.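

Going by these compounds alone, this is the first measured step at this position. In this assay, exchanging the 1-ethoxyethyl group for oxetan-2-yl at this place gives a 4.6-fold higher number from compound 2 to compound 4 (0.66 log units; beyond the scatter) and so shows that binding responds to this swap, though the step is modest. The swap replaces an open chain bearing a defined stereocentre with a four-membered ring and removes one heavy atom, while the counts of hydrogen-bond donors and acceptors and the net charge stay the same, and no further data here bear on what lies behind the step.

Several things change at once in this swap, so the compounds shown leave open whether the ring, the smaller size or the loss of the defined stereocentre accounts for the higher number. As far as these compounds go, a cyclobutyl group, which is the same ring size without the oxygen, and an open-chain methoxymethyl group at this place would help separate these possibilities, and their effects remain unknown here.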